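Replacing 3-chlorophenyl with 2-ethylphenyl: working notes

This account rests on a few compounds, and the source may have more. Where it says the series, first, only, none or still open, it means among the compounds named here.

In a functional assay on the whole organism for inhibition, with Rattus norvegicus as the target (a lower number here means that less compound is needed, a higher number that more compound is needed for the effect), compound 2 `CC(C)c1ccc(OC(C)(Cc2cccc(Cl)c2)C(=O)O)cc1` gives 5 mg/kg, level with compound 1 `CC(C)c1ccc(OC(C)(Cc2cccc(C(F)(F)F)c2)C(=O)O)cc1` at 5 mg/kg. Compound 3 `CC(C)c1ccc(OC(C)(Cc2ccc(Cl)cc2)C(=O)O)cc1` gives 1 mg/kg; 1 mg/kg; 1 mg/kg (3 entries) across its repeat entries, so the measured compounds sit at only two levels so far.

Compound 4 `CCc1ccccc1CC(C)(Oc1ccc(C(C)C)cc1)C(=O)O` has not yet been measured. Its difference from compound 2 is 2-ethylphenyl in place of 3-chlorophenyl on a saturated chain carbon, two bonds along the chain from a carbonyl carbon and an oxygen on an aromatic ring, on a saturated chain carbon, two bonds along the chain from a carbonyl carbon and an oxygen on an aromatic ring.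

Within the data shown here, one measured step bears on this change: no change at the digits printed from compound 1 to compound 2 (within the scatter), with chloro in place of trifluoromethyl on an aromatic carbon. It is only a loose guide, since it exchanges a single group on the aromatic ring, whereas here the whole substituted phenyl group is exchanged. Among the measured compounds shown here, no measured compound carries 2-ethylphenyl. The range stays wide on the low side, as compound 3 shows 1 mg/kg; 1 mg/kg; 1 mg/kg (3 entries) in the same core family.

No shift beyond the scatter is expected in either direction, so the expected step in this assay is no change at the digits printed from compound 2 to compound 4 (within the scatter). For compound 4 the estimated value is 5 mg/kg, with an expected range of 1.5 mg/kg to 15 mg/kg.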

Compound 4, dose for half-maximal effect: 5 mg/kg
Compound 4: middle estimate and measured number agree at the digits printed, and the stated range covers the measured number.
By their numbers in this assay, from the lowest: compounds 1, 2 and 4 (each within the scatter of the next).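

In this assay, exchanging the whole group on the saturated chain carbon gives no change at the digits printed from compound 2 to compound 4 (within the scatter), so at this place 2-ethylphenyl, with only carbon among its heavy atoms, stands level with 3-chlorophenyl, which carries a chlorine. Among these compounds, the earlier step, no change at the digits printed from compound 1 to compound 2 (within the scatter), exchanged only a single group on the aromatic ring, whereas this one replaces the entire substituted phenyl group and still leaves the number within the scatter. No measurement at hand explains why the number holds across this exchange.

Compound 3 gives 1 mg/kg; 1 mg/kg; 1 mg/kg (3 entries), so the shared core can reach a smaller dose than compounds 1, 2 and 4, and the compounds shown do not tell whether a phenyl group carrying ethyl can reach that level too. Also open, going by these compounds, is whether the level holds for a longer chain, as in 2-propylphenyl, or for a methoxy group or an amine on the same ring.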